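This account rests on a few compounds, and the source may have more. Where it says the series, first, only, none or still open, it means among the compounds named here.

In a functional assay on NCI-H1650 cells (Homo sapiens) for cytotoxicity, read by MTT assay, with a stated time of 72 h (on this read-out lower numbers stand for stronger inhibition and higher numbers for weaker inhibition), compound 2 `CCOC(=O)C(COC(=O)c1ccccc1)c1ccc(C(F)(F)F)cc1` gives no number, only a limit of > 0.01 ug/mL. Compound 1 `CCOC(=O)C(COC(=O)c1ccccc1OC(C)=O)c1ccc(F)cc1` likewise reads only as a limit, > 0.01 ug/mL. The two compounds therefore share one reading, (the limit of > 0.01 ug/mL in this assay, at which 2 of the 2 values shown sit), and neither can be ranked against the other. Compound 3 `CCOC(=O)C(COC(=O)c1ccccc1OC(C)=O)c1ccc(C(F)(F)F)cc1` follows from compound 2 by one structural change, acetoxy in place of hydrogen on an aromatic carbon, turning phenyl to 2-acetoxyphenyl. Going by the values given here, no measured pair isolates this change, so the data give no direct size for it. Given (the limit of > 0.01 ug/mL in this assay, at which 2 of the 2 values shown sit), only a small expected step is estimated, a step that the limit leaves unreadable from compound 2 to compound 3, towards weaker inhibition in this assay, and a further limit would not be surprising. Compound 3 is expected to read about 0.02 ug/mL, with an estimated range from 0.008 ug/mL to 0.1 ug/mL.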

Compound 3, half-maximal inhibitory concentration: > 0.01 ug/mL
Compound 3: no number, only a limit (the forecaster's own chance of this, stated with the estimate: 70%); the middle value does not contradict the limit.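

In this assay, going by these compounds alone, no step from compound 1 or compound 2 to compound 3 can be read, since all three compounds give only a limit and no number: the limit of > 0.01 ug/mL in this assay, at which 3 of the 3 values shown sit.

The compounds shown leave open whether acetoxy in place of hydrogen, or trifluoromethyl in place of fluoro, changes the inhibition at all.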